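A Sulfamoyl-for-Piperazinyl Swap Repeated on a Second Core

A few compounds are considered here, and "the series" means these few. Any claim that something is new, unique, unknown or untested is made for them only; others in the source may bear on it.

Compound 1 `CN1CCN(c2ccc(Nc3ncc(/N=C/c4cccs4)c(NC4CCCC4)n3)cc2)CC1` carries a 4-methylpiperazin-1-yl group and in a functional assay on MCF7 cells (Homo sapiens) for antiproliferative activity, read by MTT assay (a higher number here means a weaker inhibitor, a lower number a stronger inhibitor), compound 1 gives 33900 nM. Compound 2 `NS(=O)(=O)c1ccc(Nc2ncc(/N=C/c3cccs3)c(NC3CCCC3)n2)cc1` differs by sulfamoyl in place of 4-methylpiperazin-1-yl on an aromatic carbon, and in this assay compound 2 gives 23000 nM, so that a 1.5-fold lower number from compound 1 to compound 2 (0.17 log units; within the scatter). Compound 3 `CCOC(=O)/C=N/c1cnc(Nc2ccc(N3CCN(C)CC3)cc2)nc1NC(C)C` has a different core; how its core differs from that of compound 1 is not broken down here. In this assay compound 3 gives 12300 nM. Compound 4 `CCOC(=O)/C=N/c1cnc(Nc2ccc(S(N)(=O)=O)cc2)nc1NC(C)C` has not been measured; it differs from compound 3 by sulfamoyl in place of 4-methylpiperazin-1-yl on an aromatic carbon, the same change seen between compound 1 and compound 2. He expects a step of a 1.4-fold lower number from compound 3 to compound 4 (0.14 log units; within the scatter), a shift of about the size of that earlier change, because a 1.5-fold lower number from compound 1 to compound 2 (0.17 log units; within the scatter) stayed within the scatter. His estimate for compound 4 in this assay is 9000 nM, between 3500 nM and 25000 nM.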

Compound 4, half-maximal inhibitory concentration: 58800 nM
The estimate for compound 4 lay 6.5-fold (0.82 log units) below the measured number, outside the stated range (above it).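

In this assay the step on the second core is a 4.8-fold higher number from compound 3 to compound 4 (0.68 log units; beyond the scatter), so sulfamoyl in place of 4-methylpiperazin-1-yl did not behave there as it did on the core of compound 1. The change therefore cannot be carried between these two cores as a fixed shift: the same change on two cores in this assay, a 1.5-fold lower number (0.17 log units; within the scatter) from compound 1 to compound 2 and a 4.8-fold higher number (0.68 log units; beyond the scatter) from compound 3 to compound 4, 7.0-fold (0.85 log units) apart, beyond the scatter of two such steps. This shows that the outcome of the change depended on the core in these two pairs, but it does not show which part of the cores is responsible, and two pairs make no rule for the series.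

The compounds shown leave open whether another group on that aromatic carbon, such as a carboxylic acid or a primary amine, would follow either step. They also leave open which part of the cores sets the direction of the step.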